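The source may hold more compounds than are shown below. What is called first, only, known or untested is meant among the compounds shown, and "the series" means these compounds.

Compound 1 `Cc1nn(-c2nc(-c3ccc(Cl)c(Cl)c3)c(SC(C)C)s2)c(C(=O)O)c1-c1cccc(F)c1`: 900 nM in a functional assay on BJAB cells (Homo sapiens) for antiproliferative activity, with a stated time of 4 days; on this read-out higher numbers stand for an effect only at larger amounts of compound and lower numbers for an effect already at smaller amounts
Compound 2 `Cc1cc(C)cc(-c2c(C)nn(-c3nc(-c4ccc(Cl)c(Cl)c4)c(SC(C)C)s3)c2C(=O)O)c1`: 2700 nM in this assay

Compound 2 gives the higher of the two numbers; the step between them is a 3.0-fold higher number from compound 1 to compound 2 (0.48 log units; beyond the scatter). Compound 3 `COc1cc(Cl)cc(-c2c(C)nn(-c3nc(-c4ccc(Cl)c(Cl)c4)c(SC(C)C)s3)c2C(=O)O)c1` is not yet measured. It differs from compound 2 as follows: 3-chloro-5-methoxyphenyl in place of 3,5-dimethylphenyl on an aromatic carbon. Going by the values given here, the single step known so far, a 3.0-fold higher number from compound 1 to compound 2 (0.48 log units; beyond the scatter), changed the same aryl group but to a different substituent pattern, so it bears only loosely on this change and gives no clear direction. For compound 3 a step within the scatter is expected, a 1.4-fold lower number from compound 2 to compound 3 (0.13 log units; within the scatter). Compound 3 is therefore estimated at 2000 nM, in a range from 700 nM to 6000 nM.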

Compound 3, half-maximal effective concentration: 760 nM
The estimate for compound 3 lay 2.6-fold (0.42 log units) above the measured number; measured number inside the range.
By their numbers in this assay, from the lowest: compounds 3 and 1 (each within the scatter of the next); then compound 2.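

In this assay, swapping 3,5-dimethylphenyl for 3-chloro-5-methoxyphenyl at this position gives a 3.6-fold lower number from compound 2 to compound 3 (0.55 log units; beyond the scatter), so the identity of the two substituents on this phenyl ring matters, not only their number. Against the 3-fluorophenyl group, the same 3-chloro-5-methoxyphenyl group gives a 1.2-fold lower number from compound 1 to compound 3 (0.07 log units; within the scatter), which leaves compound 2 alone in standing apart from the other two. Nothing measured here explains the difference between these groups.

On these data alone, the chlorine and the methoxy group enter together, so their separate contributions remain open. As far as these compounds go, how an amine on this phenyl ring would behave also remains open.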